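From oxan-3-yl to oxan-4-yl on the shared core

The compounds below may be only part of what the source reports. "The series", "measured", "known", "first", "only" and "open" are said of these compounds alone.

In an ADME assay on the whole organism (Rattus norvegicus) for pharmacokinetics, at a dose of 0.5 mg/kg by the intravenous route (on this read-out higher numbers stand for fast clearance and lower numbers for slow clearance), compound 2 `CNC(=O)Nc1cc(Oc2cncc(OC)c2)c([C@H]2CCCOC2)cn1` gives 28.3 mL/min/kg. This lies within the scatter of compound 1 `CNC(=O)Nc1cc(Oc2cncc(OC)c2)c(C2=CCOCC2)cn1` at 41.7 mL/min/kg and of compound 3 `CNC(=O)Nc1cc(Oc2cncc(C)c2)c([C@H]2C[C@@H](O)C2)cn1` at 21.7 mL/min/kg, so the three values show no clear order. Compound 4 `CNC(=O)Nc1cc(Oc2cncc(OC)c2)c(C2CCOCC2)cn1` has the same atoms as compound 2, joined differently: oxan-4-yl in place of oxan-3-yl on an aromatic carbon. For the measured compounds named here, the only measured step at this aromatic carbon, a 1.5-fold lower number from compound 1 to compound 2 (0.17 log units; within the scatter), stays within the scatter, while compound 3 differs from compound 2 in more than one place. No change beyond the scatter is therefore expected, and the estimated step is a 1.1-fold higher number from compound 2 to compound 4 (0.03 log units; within the scatter). Compound 4 is expected at 30 mL/min/kg, with an estimated range of 17 mL/min/kg to 50 mL/min/kg.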

Compound 4, clearance: 46.7 mL/min/kg
Compound 4: middle estimate off by 1.6-fold (0.19 log units), on the low side, and the stated range covers the measured number.
By their numbers in this assay, from the lowest: compounds 3, 2, 1 and 4 (each within the scatter of the next, the first and the last beyond it).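

In this assay, oxan-4-yl in place of oxan-3-yl on this aromatic carbon gives a 1.7-fold higher number from compound 2 to compound 4 (0.22 log units; within the scatter), so moving the point of attachment around the ring does not take the number beyond the scatter. Exchanging the group of compound 1 for oxan-4-yl gives a 1.1-fold higher number from compound 1 to compound 4 (0.05 log units; within the scatter), and this step also leaves the read-out unresolved. Nothing measured here gives a reason for these numbers. The compounds shown leave open whether an amine such as piperidin-4-yl or a carboxylic acid at this aromatic carbon would change clearance beyond the scatter.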